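This account rests on a few compounds, and the source may have more. Where it says the series, first, only, none or still open, it means among the compounds named here.

Working notes on the thiosemicarbazone series.

Compound 1 `NC(=S)N/N=C/c1ccc2ccccc2n1` is the reference point. In a functional assay on HT-29 cells (Homo sapiens) for antiproliferative activity, read by sulforhodamine B assay, with a stated time of 72 h (on this read-out lower numbers stand for stronger inhibition and higher numbers for weaker inhibition), compound 1 gives 100000 nM, the highest of the three numbers in hand. Compound 2 `CN(C)C(=S)N/N=C/c1cnc2ccccc2n1` gives 450 nM and compound 3 `CN(C)C(=S)N/N=C/c1nc2ccccc2s1` gives 250 nM; both values lie beyond the scatter from that of compound 1, so compound 1 is the weakest of the measured set. Among the compounds with values here, compounds 2 and 3 differ from compound 1 in more than one place, so no single step separates them, and their numbers are read only as showing that the terminal nitrogen carries substituents in the two potent members and none in compound 1.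

Compound 4 `S=C(N/N=C/c1ccc2ccccc2n1)Nc1ccccc1Br` is not yet measured. Relative to compound 1 it carries 2-bromophenyl in place of hydrogen on an amide-type nitrogen. Within the data shown here, no measured pair in the set isolates this change. Given that compound 2 at 450 nM and compound 3 at 250 nM both carry substituents on that nitrogen, a step toward lower numbers, well beyond the scatter, is expected for compound 4, namely a 50-fold lower number from compound 1 to compound 4 (1.70 log units; beyond the scatter). Compound 4 is estimated at 2000 nM, in the range 200 nM to 30000 nM.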

Compound 4, half-maximal inhibitory concentration: > 100000 nM
Compound 4: no number, only a limit; the forecaster's own chance of this, stated with the estimate: 10%; middle value at least 50-fold (1.69 log units) from the limit.
By their numbers in this assay, from the lowest: compounds 3 and 2 (each within the scatter of the next); then compound 1.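

Within the data shown here, this is the first step at the amide-type nitrogen that changes only one place on the core of compound 1. In this assay compound 4 gives > 100000 nM, which is a limit and not a number. The step reads a number no lower from compound 1 to compound 4 (the limit leaves the size open), so 2-bromophenyl in place of hydrogen at this position brings no gain on this core, and a substituent on that nitrogen does not by itself go with a low number; this reading rests on a limit: the limit of > 100000 nM in this assay, at which 1 of the 4 values shown sits.

Still open, on these data alone, is how far compound 4 lies from compound 1, and whether the bromine or the phenyl ring governs the outcome. A plain phenyl, a methyl or a morpholine on this nitrogen of the same core would separate these readings.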